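The compounds below may be only part of what the source reports. "The series", "measured", "known", "first", "only" and "open" are said of these compounds alone.

Measured compounds:
compound 1, `CCCCc1cc(OC)c2ccccc2c1OC(C)=O`, 440 nM
compound 2, `CCCCc1cc(OC)c2c(C)cccc2c1OC(C)=O`, 620 nM
compound 3, `CCc1c(CC)c(OC)c2c(C)cccc2c1OC(C)=O`, 830 nM

Notes. All three numbers come from a functional assay for inhibition, with Rattus norvegicus as the target; on this read-out lower numbers stand for stronger inhibition and higher numbers for weaker inhibition. Compound 1 and compound 2 differ in one place: methyl in place of hydrogen on an aromatic carbon The step that goes with this change is a 1.4-fold higher number from compound 1 to compound 2 (0.15 log units; within the scatter). Compound 3 stands at the highest of the three numbers, but its gaps to compound 2 and to compound 1 are both within the scatter, so no order among the three can be read from these values. How the core of compound 3 differs from the core of compound 1 is not broken down here.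

Compound 4, `CCc1c(CC)c(OC(C)=O)c2c(C)ccc(C)c2c1OC`, is not yet measured. Within the data shown here, it differs from compound 3 as follows: methyl in place of hydrogen on an aromatic carbon This is the same kind of change as the one from compound 1 to compound 2, not the same change: in compound 4 the entering methyl also sits para to a methyl group, which has no counterpart around the place in compound 2.

Expectation. Among the measured compounds shown here, with only one earlier example of this kind of change, the step from compound 3 to compound 4 is expected to be about a 1.3-fold higher number from compound 3 to compound 4 (0.12 log units; within the scatter), in line with the measured step, because a 1.4-fold higher number from compound 1 to compound 2 (0.15 log units; within the scatter) stayed within the scatter and nothing here points the new one elsewhere. Going by these compounds, on that basis compound 4 is estimated at 1100 nM in this assay, with a range from 550 nM to 2400 nM; the added para relation in compound 4 is untested, so the range is kept wide.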

Compound 4, half-maximal inhibitory concentration: 13000 nM
For compound 4 the middle estimate is 12-fold (1.07 log units) below the measured one; the measured number lies above the stated range.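

In this assay methyl in place of hydrogen on an aromatic carbon gives a 16-fold higher number from compound 3 to compound 4 (1.19 log units; beyond the scatter) and so does not repeat the earlier example of this change: the same change on two cores in this assay, a 1.4-fold higher number (0.15 log units; within the scatter) from compound 1 to compound 2 and a 16-fold higher number (1.19 log units; beyond the scatter) from compound 3 to compound 4, 11-fold (1.05 log units) apart, beyond the scatter of two such steps. In this series, the size of the step on the core of compound 1 is therefore no guide to its size on the core of compound 3, and the change cannot be carried from one core to another as a fixed increment. Among these compounds, the two steps do not show what sets them apart: the cores differ, and in compound 4 the entering methyl is also para to a methyl group, which has no counterpart in compound 2, so the two differences cannot be separated with one step on each core.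

Still open is whether the large step belongs to the methyl itself or to the place it occupies, as the compounds shown carry no other group there, such as a fluorine atom or a longer chain like propyl. Also open, going by these compounds, is whether a methyl para to a methyl group on the core of compound 1 would give a similar step.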